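The compounds below may be only part of what the source reports. "The series", "measured", "known", "first", "only" and "open" are said of these compounds alone.

Compound 1, `COc1cc(C(=O)N/N=C/c2ccc(F)c(F)c2)cc(OC)c1OC`, carries a 3,4-difluorophenyl group on the carbon double-bonded to nitrogen. In a functional assay on BGC-823 cells (Homo sapiens) for antiproliferative activity, read by MTT assay, tested at 1 uM (a lower number here means a weaker effect, a higher number a stronger effect of the compound at the concentration tested), compound 1 gives 33.1%, the highest of the three numbers shown, though compound 3, `COc1cc(C2=NN(C(C)=O)C(c3ccccc3C(F)(F)F)O2)cc(OC)c1OC`, gives 31.8%, which lies within the scatter of it; compound 2, `COc1ccc(C2OC(c3cc(OC)c(OC)c(OC)c3)=NN2C(C)=O)c(OC)c1`, gives 6.3%, beyond the scatter. For the measured compounds named here, the only measured step, a number 25.5 percentage points higher from compound 2 to compound 3 (beyond the scatter), concerns an aryl swap on a saturated ring carbon of a different core, so it bears on the present change only loosely, showing that exchanging one aryl group for another can move this read-out by a modest amount. Compound 4, `COc1cc(C(=O)N/N=C/c2cc(Cl)cc(Cl)c2)cc(OC)c1OC`, differs from compound 1 by 3,5-dichlorophenyl in place of 3,4-difluorophenyl on a carbon with a double bond to nitrogen. Going by the values given here, no measured pair shows a halogen pattern swap on the core of compound 1, so the step is expected to stay within the scatter: the step of a number 0.1 percentage points lower from compound 1 to compound 4 (within the scatter) is the estimate. Compound 4 is therefore expected to give about 33%, with a range of 15% to 50%.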

Compound 4, a percentage reported as inhibition, at one concentration (the size of the read-out at that concentration, not a potency): -7.5%
For compound 4 the middle estimate is 40.5 percentage points above the measured one; measured number below the stated range.
By their numbers in this assay, from the lowest: compound 4; then compound 2; then compounds 3 and 1 (each within the scatter of the next).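

On the core of compound 1, the aryl group on the carbon with a double bond to nitrogen turns out not to be a tolerant place in this assay: a number 40.6 percentage points lower from compound 1 to compound 4 (beyond the scatter), a large step, although the leaving and entering groups count the same heavy atoms and the same ring. The swap changes the halogen and its ring pattern together, so this single step cannot assign the loss to either one. No measurement at hand accounts for the drop.

The compounds shown leave open whether the chlorine atoms or their pattern in 3,5-dichlorophenyl goes with the loss, a question that 3,4-dichlorophenyl at this place would bear on. They also leave open how a phenyl ring carrying a hydroxyl group or an amine would read here.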